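Methyl to methoxy on a triazole-linked dithiocarbamate series

The source may report more compounds than this note shows. Statements on the series, on what has been measured and on what is new or still open speak of the compounds shown alone.

Measured compounds:
compound 1 `COc1ccc(-n2cc(CSC(=S)N3CCN(C(=O)OC(C)(C)C)CC3)nn2)cc1`: > 128000 nM
compound 2 `Cc1ccc(-n2cc(CSC(=S)N3CCN(C(=O)OC(C)(C)C)CC3)nn2)cc1`: > 128000 nM
compound 3 `Cc1ccc(Cn2cc(CSC(=S)N3CCNCC3)nn2)cc1`: 19800 nM

In a functional assay on PC-3 cells (Homo sapiens) for inhibition, read by MTT assay, with a stated time of 72 h (on this read-out higher numbers stand for weaker inhibition and lower numbers for stronger inhibition), compound 1 reaches only the limit of the assay, > 128000 nM. In this assay compound 2 likewise sits at a limit, > 128000 nM. For the measured compounds named here, compound 3 is the one compound with a number in this assay, 19800 nM. The change from compound 2 to compound 1 is methoxy in place of methyl on an aromatic carbon, and its step in this assay, a step that the two limits leave unreadable from compound 2 to compound 1, cannot be read because of the limit of > 128000 nM in this assay, at which 2 of the 3 values shown sit.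

Compound 4 `COc1ccc(Cn2cc(CSC(=S)N3CCNCC3)nn2)cc1` is not yet measured. How the core of compound 3 differs from that of compound 2 is not broken down here. The change from compound 3 to compound 4 is methoxy in place of methyl on an aromatic carbon, the same change as from compound 2 to compound 1, at the same place.

Going by the values given here, since the one measured instance of this change gives no readable size, the step from compound 3 to compound 4 in this assay is expected to be small, a 1.0-fold higher number from compound 3 to compound 4 (0.00 log units; within the scatter), resting only on the value of compound 3, 19800 nM. Compound 4 is therefore estimated at 20000 nM, most likely between 7000 nM and 60000 nM.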

Compound 4, half-maximal inhibitory concentration: > 128000 nM
Compound 4 was reported as a limit; the forecaster's own chance of this, stated with the estimate: 10%; middle value at least 6.4-fold (0.80 log units) away from the limit.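

In this assay, methoxy in place of methyl on an aromatic carbon gives an at least 6.4-fold higher number from compound 3 to compound 4 (0.81 log units; beyond the scatter), a loss of inhibition on this core whose full size is not known. Compound 4 gives > 128000 nM, which is a limit of the assay and not a number. The same change on the core of compound 2 cannot be read, so the series does not show whether the step carries from one core to another, because both compounds of that pair sit at the limit: the limit of > 128000 nM in this assay, at which 3 of the 4 values shown sit.

From the compounds shown here alone, only methyl and methoxy appear at this place on the core of compound 3, so it stays open whether an amine, a carboxylic acid or a longer chain such as ethoxy there would keep a measurable number close to that of compound 3, 19800 nM. With a single number among the compounds shown, it also stays open how the two cores compare when they carry the same group.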